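The compounds below may be only part of what the source reports. "The series", "measured", "known", "first", "only" and "open" are said of these compounds alone.

Measured compounds:
- compound 1, `O=C(O)C[C@@H](NC(=O)[C@@H]1CCN1S(=O)(=O)c1cc(Cl)cc(Cl)c1)c1ccc(OC2CC2)cc1`; in an assay on RPMI-8866 cells for inhibition of integrin alpha-4/beta-1 (Homo sapiens) (on this read-out higher numbers stand for weaker inhibition and lower numbers for stronger inhibition), compound 1 gives 0.31 nM
- compound 2, `O=C(O)C[C@@H](NC(=O)[C@@H]1CCN1S(=O)(=O)c1cc(Cl)cc(Cl)c1)c1ccc(Br)cc1`; in this assay compound 2 gives 2.1 nM
- compound 3, `O=C(O)C[C@@H](NC(=O)[C@@H]1CCN1S(=O)(=O)c1cc(Cl)cc(Cl)c1)c1ccc(Oc2ccccc2)cc1`; in this assay compound 3 gives 3.1 nM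

Compound 3 carries the highest of the three numbers. Its gap to compound 2, a 1.5-fold higher number from compound 2 to compound 3 (0.17 log units; within the scatter), is within the scatter, so the two cannot be ordered; its gap to compound 1, a 10-fold higher number from compound 1 to compound 3 (1.00 log units; beyond the scatter), is beyond the scatter.

Compound 4 is `O=C(O)C[C@@H](NC(=O)[C@@H]1CCN1S(=O)(=O)c1cc(Cl)cc(Cl)c1)c1ccc(OCC(F)(F)F)cc1`. The change from compound 3 is 2,2,2-trifluoroethyl in place of phenyl on an oxygen on an aromatic ring; cut one bond further out it reads phenoxy to 2,2,2-trifluoroethoxy. Among the compounds with values here, the step that bears on it is the one from compound 1 to compound 3, where phenyl in place of cyclopropyl on the same oxygen gave a 10-fold higher number from compound 1 to compound 3 (1.00 log units; beyond the scatter). Compound 4 reverses the phenyl part of that change, replacing it with another small group without a ring, so a step to a lower number is expected, of a size up to that of the compound 1 to compound 3 step, though the new group is not cyclopropyl and the match is not exact. The step from compound 3 to compound 4 is therefore estimated at a 4.4-fold lower number from compound 3 to compound 4 (0.65 log units; beyond the scatter). Compound 4 is expected to give 0.7 nM in this assay, within a range of 0.2 nM to 2.5 nM.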

Compound 4, half-maximal inhibitory concentration: 1.4 nM
Compound 4: middle estimate off by 2.0-fold (0.30 log units), on the low side; low and high end bracket the measured number.
By their numbers in this assay, from the lowest: compound 1; then compounds 4, 2 and 3 (each within the scatter of the next, the first and the last beyond it).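

In this assay, the ring-free 2,2,2-trifluoroethyl on this oxygen gives a 2.2-fold lower number from compound 3 to compound 4 (0.35 log units; beyond the scatter), so a lower number than that of phenyl does not depend on an aromatic ring here. Set against cyclopropyl on the same oxygen, the same group gives a 4.5-fold higher number from compound 1 to compound 4 (0.65 log units; beyond the scatter), which separates the three oxygen substituents into a clear order: cyclopropyl with the lowest number, then 2,2,2-trifluoroethyl, then phenyl. Against bromo on the aromatic carbon, 2,2,2-trifluoroethoxy gives a 1.5-fold lower number from compound 2 to compound 4 (0.18 log units; within the scatter), so these two cannot be ordered.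

No measured data bear on the reason for these differences. On these data alone, whether the advantage of cyclopropyl lies in its ring or the gap to 2,2,2-trifluoroethyl lies in the fluorine remains open, and an ethyl or cyclobutyl group on this oxygen would help separate the two.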